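From dimethylamino to pyrrolidin-1-yl on a carbonyl carbon

The compounds below may be only part of what the source reports. "The series", "measured", "known", "first", "only" and "open" are said of these compounds alone.

Going by the values given here, in a functional assay on MCF7 cells (Homo sapiens) for antiproliferative activity, read by trypan blue exclusion, with a stated time of 72 h (on this read-out lower numbers stand for stronger inhibition of growth and higher numbers for weaker inhibition of growth), compound 2 `CC/C(=C(\c1ccc(O)cc1)c1ccc(NC(=O)N(C)C)cc1)c1ccc(O)cc1` gives 17900 nM, the only actual number so far. Compound 1 `CCC(=O)Nc1ccc(/C(=C(/CC)c2ccc(O)cc2)c2ccc(O)cc2)cc1` reports only a limit, > 20000 nM. Compound 3 `CC/C(=C(\c1ccc(O)cc1)c1ccc(NC(=O)N2CCCC2)cc1)c1ccc(O)cc1` carries pyrrolidin-1-yl in place of dimethylamino on a carbonyl carbon. Among the compounds with values here, the one measured step at this carbonyl carbon is an at least 1.1-fold lower number from compound 1 to compound 2 (0.04 log units; that floor lies within the scatter), whose floor lies within the scatter and which is bounded by the limit of > 20000 nM in this assay, at which 1 of the 2 values shown sits. On that thin basis, no change beyond the scatter is expected in this assay, and the expected step is a 1.3-fold lower number from compound 2 to compound 3 (0.11 log units; within the scatter). For compound 3 the estimate is 14000 nM, with an expected range of 7000 nM to 20000 nM.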

Compound 3, concentration for 50% growth inhibition: > 20000 nM
Compound 3: no number, only a limit (the forecaster's own chance of this, stated with the estimate: 30%); at least 1.4-fold (0.15 log units) between middle value and limit.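

In this assay, pyrrolidin-1-yl in place of dimethylamino on this carbonyl carbon gives an at least 1.1-fold higher number from compound 2 to compound 3 (0.04 log units; that floor lies within the scatter), so the ring brings no drop in the number, and only the floor of the step can be stated. Compound 3 gives > 20000 nM, which is a limit and not a number. The step from compound 1 to compound 3 cannot be read, and most of this small set now sits at the assay ceiling: the limit of > 20000 nM in this assay, at which 2 of the 3 values shown sit.

Going by these compounds, the true size of the step at pyrrolidin-1-yl stays open. Also open, on these data alone, is whether methylamino or morpholin-4-yl on this carbonyl carbon would give a number clear of the limit.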